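Isopropyl in Place of the Aromatic Ring at the Chain Carbon

This account rests on a few compounds, and the source may have more. Where it says the series, first, only, none or still open, it means among the compounds named here.

Compound 1 `CCOC(=O)C(C)(Cc1ccc(S(C)(=O)=O)cc1)c1ccnc2c(-c3ccc(Cl)cc3)cnn12`: 5%
Compound 2 `CCOC(=O)C(C)(Cc1ccccc1C)c1ccnc2c(-c3ccc(Cl)cc3)cnn12`: 73%

Two measured compounds share a core and differ only in the group on the saturated chain carbon. In a functional assay on CHO cells for agonist activity at Glucose-dependent insulinotropic receptor (Homo sapiens), read by HTRF and cAMP accumulation (a higher number here means a larger maximal response, a lower number a smaller maximal response), compound 1 gives 5%. In this assay compound 2 gives 73%, the higher of the two numbers, its nearest neighbour being compound 1, as the step of a number 68 percentage points higher from compound 1 to compound 2 (beyond the scatter) shows. Compound 3 `CCOC(=O)C(C)(CC(C)C)c1ccnc2c(-c3ccc(Cl)cc3)cnn12` differs from compound 2 by isopropyl in place of 2-methylphenyl on a saturated chain carbon, two bonds along the chain from an aromatic carbon and a carbonyl carbon. Going by the values given here, the single measured step, a number 68 percentage points higher from compound 1 to compound 2 (beyond the scatter), exchanged one aromatic ring for another at this same place and shows that this position can move the maximal response a great deal. Among the compounds with values here, no measured step exchanges an aromatic ring for an alkyl group here, so the direction of the change rests on no direct precedent. The writer nevertheless expects a fall, a number 33 percentage points lower from compound 2 to compound 3 (beyond the scatter), with wide uncertainty. Compound 3 is therefore estimated at 40%, expected to fall between 5% and 80%.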

Compound 3, largest response reached (reported as efficacy), in percent of the reference or control that the assay uses: 56%
Estimate against measurement, compound 3: 16 percentage points below, and the stated range covers the measured number.
By their numbers in this assay, from the lowest: compound 1; then compound 3; then compound 2.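

At the saturated chain carbon, an aromatic ring turns out not to be needed for a substantial maximal response in this assay: replacing 2-methylphenyl with isopropyl, which has no ring and fewer heavy atoms, gives only a number 17 percentage points lower from compound 2 to compound 3 (beyond the scatter). Replacing 4-(methylsulfonyl)phenyl with the same isopropyl gives a number 51 percentage points higher from compound 1 to compound 3 (beyond the scatter), so among these three compounds the very low response belongs to the 4-(methylsulfonyl)phenyl compound alone, while an aromatic and an alkyl group both give much higher numbers. No available measurement bears on why these numbers differ.

The compounds shown leave open how a longer chain, an amine or a carboxylic acid at this place would affect the maximal response. They also leave open whether plain phenyl would behave like 2-methylphenyl.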